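Chain extension on the benzyl side of the thiourea core

The source may hold more compounds than are shown below. What is called first, only, known or untested is meant among the compounds shown, and "the series" means these compounds.

Compound 1 `CCc1ccc(C/N=C(\S)NCc2ccc(NS(C)(=O)=O)c(F)c2)cc1` carries an ethyl chain on its aromatic ring, and in an assay for inhibition of transient receptor potential cation channel subfamily V member 1 (Rattus norvegicus), with a stated time of 10 min (a higher number here means a weaker inhibitor, a lower number a stronger inhibitor), compound 1 gives 1100 nM. Compound 2 `CCCc1ccc(C/N=C(\S)NCc2ccc(NS(C)(=O)=O)c(F)c2)cc1` carries a propyl chain in the same place; in this assay compound 2 gives 460 nM. For the measured compounds named here, the one measured step, a 2.4-fold lower number from compound 1 to compound 2 (0.38 log units; beyond the scatter), shows that one added chain carbon lowers the number. Going by the values given here, compound 2 thus stands lowest of the two numbers in hand, with compound 1 as its only neighbour.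

Compound 3 `CCCCc1ccc(C/N=C(\S)NCc2ccc(NS(C)(=O)=O)c(F)c2)cc1` extends the chain once more: methyl in place of hydrogen on a saturated chain carbon, three bonds along the chain from an aromatic carbon. Among the compounds with values here, the only step that bears on this change is a 2.4-fold lower number from compound 1 to compound 2 (0.38 log units; beyond the scatter), a modest lowering beyond the scatter; no second example shows whether a further carbon continues in the same direction or flattens out. A step of the same sign but smaller is therefore expected, the change from propyl to butyl being read as a weaker repeat of the change from ethyl to propyl. The expected step is a 1.5-fold lower number from compound 2 to compound 3 (0.19 log units; within the scatter). For compound 3 in this assay the estimate is 300 nM, within a range from 120 nM to 750 nM.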

Compound 3, half-maximal inhibitory concentration: 470 nM
Estimate against measurement, compound 3: 1.6-fold (0.19 log units) below; the measured number falls inside the stated range.
By their numbers in this assay, from the lowest: compounds 2 and 3 (each within the scatter of the next); then compound 1.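

Adding a carbon at this place, three bonds along the chain from an aromatic carbon, gives a 1.0-fold higher number from compound 2 to compound 3 (0.01 log units; within the scatter) in this assay and so does not repeat the beyond-scatter lowering seen for the change from ethyl to propyl; compound 2 and compound 3 cannot be told apart here. The advantage over the ethyl chain is nevertheless retained, with a 2.3-fold lower number from compound 1 to compound 3 (0.37 log units; beyond the scatter) alongside a 2.4-fold lower number from compound 1 to compound 2 (0.38 log units; beyond the scatter) in the same assay, so among these three compounds the propyl and butyl chains form one level and the ethyl chain stands apart from it. No measurement at hand bears on why the series levels off at propyl and butyl.

Still open, as far as these compounds go, is whether a longer chain such as pentyl or hexyl stays on this level or moves the number in either direction, and whether a branched chain such as isobutyl behaves like its straight counterpart. Also open, from the compounds shown here alone, is what a terminal amine or carboxylic acid at the end of the chain would do to the number in this assay on the same core.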